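Working notes: compound 2 to compound 3

This account rests on a few compounds, and the source may have more. Where it says the series, first, only, none or still open, it means among the compounds named here.

Measured so far:
Compound 1 `Cc1ccc(-n2cc(Cn3cc(CO)nn3)c(-c3ccccc3)n2)cc1`: 8700 nM
Compound 2 `COc1ccc(-c2nn(-c3ccccc3)cc2Cn2cc(CO)nn2)cc1`: 9500 nM

Of the compounds shown here, two have been measured in a functional assay on U-937 cells (Homo sapiens) for inhibition, read by ELISA, with stated times of 1 h and 24 h; on this read-out lower numbers stand for stronger inhibition and higher numbers for weaker inhibition. Compound 2 has the highest of the two numbers, but compound 1 sits within the scatter of it, so nothing separates the pair. Going by the values given here, no step between measured compounds is available, and the series gives no read on how this assay answers to any single change.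

Compound 3 `OCc1cn(Cc2cn(-c3ccccc3)nc2-c2ccc(Cl)cc2)nn1` is the next compound. It differs from compound 2 in one place: chloro in place of methoxy on an aromatic carbon. The measured pair holds no exchange of this kind, so the size of the step rests on expectation alone. The expected 1.2-fold lower number from compound 2 to compound 3 (0.07 log units; within the scatter) is small, in either direction, and most likely not beyond the scatter. Compound 3 is therefore estimated at 8000 nM, with a range from 3000 nM to 25000 nM.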

Compound 3, half-maximal inhibitory concentration: 6230 nM
Compound 3: middle estimate off by 1.3-fold (0.11 log units), on the high side; measured number inside the range.
By their numbers in this assay, from the lowest: compounds 3, 1 and 2 (each within the scatter of the next).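

In this assay, going by these compounds alone, the change from 4-methoxyphenyl to 4-chlorophenyl gives a 1.5-fold lower number from compound 2 to compound 3 (0.18 log units; within the scatter) and is the first single change that can be read. On this aromatic carbon, para to a large group, chloro in place of methoxy does not separate the two compounds, although one heavy atom replaces two and the hydrogen-bond acceptor of methoxy leaves. Nothing available accounts for the size of this step.

The compounds shown leave open whether any group at this place can move the number beyond the scatter, as methoxy and chloro are the only two compared here on an otherwise unchanged core. An amine, a carboxylic acid or a longer chain such as butoxy on this carbon would put that question to a more distant kind of group.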